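Ring opening at the aromatic carbon: compound 2 to compound 4

The source may report more compounds than this note shows. Statements on the series, on what has been measured and on what is new or still open speak of the compounds shown alone.

Measured compounds:
compound 1 `COc1ccc(Nc2cc(C3CCCCC3)oc(=O)c2)cc1`; in a functional assay on A549 cells (Homo sapiens) for cytotoxicity, read by MTT assay, with a stated time of 72 h (a higher number here means that more compound is needed for the effect, a lower number that less compound is needed), compound 1 gives 4.62 uM
compound 2 `COc1ccc(Nc2cc(C3CCCC3)oc(=O)c2)cc1`; in this assay compound 2 gives 5.42 uM
compound 3 `O=c1cc(Nc2ccccc2)cc(-c2ccccc2)o1`; in this assay compound 3 gives 0.12 uM

Compound 2 has the highest number of the three in this assay. Compound 1 lies nearest, within the scatter, and compound 3 furthest, beyond it. Compound 4, `CCCCCc1cc(Nc2ccc(OC)cc2)cc(=O)o1`, differs from compound 2 in one place: pentyl in place of cyclopentyl on an aromatic carbon.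

Within the data shown here, only one measured step touches the same aromatic carbon, a 1.2-fold higher number from compound 1 to compound 2 (0.07 log units; within the scatter), and it left the number within the scatter. Among the measured compounds shown here, no measured step exchanges a ring for a chain at this carbon, so nothing shows how the series answers that. Compound 3 differs from compound 2 in more than one place, and its far lower number therefore cannot be laid on this carbon alone.

On this basis the expected step is a 1.1-fold higher number from compound 2 to compound 4 (0.04 log units; within the scatter), with no movement beyond the scatter. For compound 4 in this assay the estimate is 6 uM, with a range from 2.5 uM to 15 uM.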

Compound 4, concentration for half-maximal effect: 4.42 uM
The estimate for compound 4 lay 1.4-fold (0.13 log units) above the measured number, and the stated range covers the measured number.
By their numbers in this assay, from the lowest: compound 3; then compounds 4, 1 and 2 (each within the scatter of the next).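

In this assay, replacing the ring with an open chain on the aromatic carbon next to the ring oxygen gives a 1.2-fold lower number from compound 2 to compound 4 (0.09 log units; within the scatter), and pentyl in place of cyclohexyl gives a 1.0-fold lower number from compound 1 to compound 4 (0.02 log units; within the scatter). Among compounds 1, 2 and 4, a ring at this carbon is therefore not required: cyclohexyl, cyclopentyl and pentyl cannot be told apart in this assay, which the earlier ring-to-ring step alone could not show. No measured evidence bears on why these three groups read alike.

As far as these compounds go, whether a much shorter chain such as methyl, a longer chain such as octyl, or a chain ending in an amine would keep the number at this carbon remains open. From the compounds shown here alone, compound 3, at 0.12 uM, differs from these compounds in more than one place, so the effect of an aromatic ring alone at this carbon also remains open.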